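A few compounds are considered here, and "the series" means these few. Any claim that something is new, unique, unknown or untested is made for them only; others in the source may bear on it.

Working notes on the series in a functional assay on Huh-7 cells (Homo sapiens) for inhibition, read by sulforhodamine B assay, with a stated time of 72 h; a lower number here means a stronger inhibitor, a higher number a weaker inhibitor.

Three compounds of a shared core carry measurements. Compound 1 `Cc1ccc(C2=Nn3c(nnc3C(C)c3ccc(CC(C)C)cc3)SC2)cc1` gives 5000 nM in this assay. Compound 2 `COc1ccc2cc(C(C)c3nnc4n3N=C(c3ccc([N+](=O)[O-])cc3)CS4)ccc2c1` gives 14700 nM in this assay. Compound 3 `CC(c1ccc(-c2ccccc2)c(F)c1)c1nnc2n1N=C(c1ccc(OC(F)(F)F)cc1)CS2` gives 8400 nM in this assay. Compound 2 thus carries the highest number of the three; its gap to compound 3 lies within the usual scatter of repeated measurements, so no order between those two can be read, while its gap to compound 1 lies beyond that scatter.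

The next compound, compound 4 `COc1ccc2cc(C(C)c3nnc4n3N=C(c3ccc(OC(F)(F)F)cc3)CS4)ccc2c1`, is compound 2 with a single change: trifluoromethoxy in place of nitro on an aromatic carbon. Among the measured compounds shown here, no pair of measured compounds differs in exactly this way, so no measured step of this kind is known. For the measured compounds named here, the only cross-reference is compound 3, which carries the same entering group on a different remainder of the molecule and gives 8400 nM in this assay, a number sitting within the scatter of compound 2.

On that basis the change from compound 2 to compound 4 is expected to give a small step, a 1.5-fold lower number from compound 2 to compound 4 (0.17 log units; within the scatter), not clearly beyond the scatter and if anything towards a lower number. Compound 4 is estimated at 10000 nM in this assay, with a range from 4000 nM to 25000 nM.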

Compound 4, half-maximal inhibitory concentration: 16000 nM
Compound 4: the middle estimate sits 1.6-fold (0.20 log units) below what was measured, and the stated range covers the measured number.
By their numbers in this assay, from the lowest: compounds 1, 3, 2 and 4 (each within the scatter of the next, the first and the last beyond it).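

In this assay, trifluoromethoxy in place of nitro, on an aromatic carbon para to a large group, gives a 1.1-fold higher number from compound 2 to compound 4 (0.04 log units; within the scatter). Among the compounds shown here, this is the first measured step at this position, and it shows that, with the rest of compound 2 held fixed, this exchange does not separate the two groups in this read-out. Nothing measured here bears on why the two groups read alike.

From the compounds shown here alone, whether any group at this position can move the number beyond the scatter remains open, as only nitro and trifluoromethoxy are compared on this remainder, and an amine, a carboxylic acid or a longer chain in their place could show whether the position matters at all. Compounds 1 and 3 differ from compound 4 in more than one place, so the gap between compound 1 and compound 4 cannot be assigned to any single part of the molecule, and it is also unknown whether the same exchange would read the same way on another remainder.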